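A Methoxy Step Repeated on a Larger Compound

The source may report more compounds than this note shows. Statements on the series, on what has been measured and on what is new or still open speak of the compounds shown alone.

Measured so far in a functional assay on NCI-H460 cells (Homo sapiens) for cytotoxicity, read by MTT assay, with a stated time of 24 h; a higher number here means a weaker inhibitor, a lower number a stronger inhibitor:
Compound 1 `C#CCn1c(=O)c(C=O)cc2ccccc21` gives > 100000 nM, a limit of the assay.
Compound 2 `C#CCn1c(=O)c(C=O)cc2cc(OC)ccc21` gives > 100000 nM, also a limit.
Compound 3 `C#CCn1c(=O)c(/C=C/C(=O)/C=C(O)/C=C/c2ccc(O)c(OC)c2)cc2ccccc21` gives 25400 nM.

From compound 1 to compound 2 the change is methoxy in place of hydrogen on an aromatic carbon, and the step is a step that the two limits leave unreadable from compound 1 to compound 2 because of the limit of > 100000 nM in this assay, at which 2 of the 3 values shown sit. Compound 3 and compound 1 differ by a large part of the molecule; the difference between the two cores is not broken down here. Compound 4 `C#CCn1c(=O)c(/C=C/C(=O)/C=C(O)/C=C/c2ccc(O)c(OC)c2)cc2cc(OC)ccc21` awaits measurement in this assay. It differs from compound 3 by methoxy in place of hydrogen on an aromatic carbon, the same change as that from compound 1 to compound 2. Because that earlier step is a step that the two limits leave unreadable from compound 1 to compound 2, the expectation rests on compound 3 and its value 25400 nM. The expected step is a 1.2-fold lower number from compound 3 to compound 4 (0.06 log units; within the scatter), within the usual scatter. Compound 4 is therefore estimated at 22000 nM, between 8000 nM and 60000 nM.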

Compound 4, half-maximal inhibitory concentration: 38100 nM
Estimate against measurement, compound 4: 1.7-fold (0.24 log units) below; the range from low to high includes it.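

In this assay methoxy in place of hydrogen on an aromatic carbon gives a 1.5-fold higher number from compound 3 to compound 4 (0.18 log units; within the scatter) and so leaves the two compounds on the larger core indistinguishable. This is a single readable step, and it does not show whether the change behaves alike on the two cores. The same change on the smaller compounds cannot be read, because both of them sit at a limit of the assay: the limit of > 100000 nM in this assay, at which 2 of the 4 values shown sit.

The compounds shown leave open whether a different group on that aromatic carbon, such as an amine or a carboxylic acid, would give a step beyond the scatter. They also leave open whether methoxy on another carbon of that ring would do so.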